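The compounds below may be only part of what the source reports. "The series", "measured", "known", "first", "only" and "open" are said of these compounds alone.

Measured so far in a functional assay on HepG2 cells (Homo sapiens) for antiproliferative activity, read by XTT assay, with a stated time of 72 h; on this read-out higher numbers stand for weaker inhibition and lower numbers for stronger inhibition:
compound 1 `Cc1nc(N)c2c(-c3ccccc3)cn([C@@H]3O[C@H](CO)[C@@H](O)[C@H]3O)c2n1` — > 20000 nM
compound 2 `Cc1nc(N)c2c(-c3cccs3)cn([C@@H]3O[C@H](CO)[C@@H](O)[C@H]3O)c2n1` — > 20000 nM
compound 3 `CNc1ncnc2c1c(-c1ccccc1)cn2[C@@H]1O[C@H](CO)[C@@H](O)[C@H]1O` — > 20000 nM

In this assay compound 1 gives > 20000 nM, which is a limit of the assay. Compound 2 gives > 20000 nM, also a limit. Compound 3 gives > 20000 nM, again a limit. The change thiophen-2-yl in place of phenyl on an aromatic carbon yields a step that the two limits leave unreadable from compound 1 to compound 2; (the limit of > 20000 nM in this assay, at which 3 of the 3 values shown sit). The difference between the core of compound 1 and the core of compound 3 is not broken down here.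

Compound 4 `CNc1ncnc2c1c(-c1cccs1)cn2[C@@H]1O[C@H](CO)[C@@H](O)[C@H]1O` carries the same change on the core of compound 3, (thiophen-2-yl in place of phenyl on an aromatic carbon). The expected step is a step that the limit leaves unreadable from compound 3 to compound 4, worded as an estimate only. It rests on a step that the two limits leave unreadable from compound 1 to compound 2, which gives no readable size. It rests also on compound 3, whose value > 20000 nM is a limit. Compound 4 is therefore expected at 35000 nM, most likely reported as a limit again, within 8000 nM to 200000 nM.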

Compound 4, half-maximal inhibitory concentration: > 20000 nM
Compound 4 gave a limit, no number; the forecaster's own chance of this, stated with the estimate: 85%; the middle value does not contradict the limit.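

In this assay compound 4 gives > 20000 nM as a limit. Going by these compounds alone, no step from compound 3 to compound 4 can be read, since both values are limits: the limit of > 20000 nM in this assay, at which 4 of the 4 values shown sit. The compounds shown leave open how thiophen-2-yl and phenyl compare on either core, as no value here is a readable number.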